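Taking the sulfonyl arm off compound 3

A few compounds are considered here, and "the series" means these few. Any claim that something is new, unique, unknown or untested is made for them only; others in the source may bear on it.

Values in a functional assay for binding affinity, with Homo sapiens as the target, read by fluorescence and flow cytometry; a higher number here means weaker binding, a lower number tighter binding:
- compound 1 `O=C(NC[C@H](NS(=O)(=O)c1ccc(Cl)cc1)C(=O)O)c1cc2cc(CCC3CCNCC3)sc2s1` gives 0.026 nM
- compound 2 `O=C(NC[C@H](NS(=O)(=O)c1cccs1)C(=O)O)c1cc2sc(CCC3CCNCC3)cc2s1` gives 0.092 nM
- compound 3 `O=C(NC[C@H](NS(=O)(=O)c1ccccc1)C(=O)O)c1cc2sc(CCC3CCNCC3)cc2s1` gives 0.15 nM

Compound 3 lies within the scatter of compound 2, while compound 1 has a lower number, beyond the scatter. All three bind very tightly, and all three carry an aromatic ring on a sulfonyl sulfur.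

Compound 4 `O=C(O)CCNC(=O)c1cc2sc(CCC3CCNCC3)cc2s1` gives that feature up. It has hydrogen in place of (phenylsulfonyl)amino on a saturated chain carbon bound to a carbonyl carbon and a saturated chain carbon. The ring goes, and so does the whole group that holds it.

For the measured compounds named here, only one measured step bears on this, and only partly. The step of a 1.6-fold higher number from compound 2 to compound 3 (0.21 log units; within the scatter) swaps one ring on the sulfonyl sulfur for another and stays within the scatter. Going by the values given here, it says nothing about removing the group altogether, since no measured compound lacks it. The size of this change is therefore poorly constrained, but a removal this large should not pass unnoticed. The expected result is a 20-fold higher number from compound 3 to compound 4 (1.30 log units; beyond the scatter) and this estimate points to a clearly higher number, beyond the scatter. Compound 4 is estimated at 3 nM with an expected range from 0.3 nM to 30 nM in this assay.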

Compound 4, dissociation constant: about 600 nM
Beside the measured number, compound 4's estimate is 200-fold (2.30 log units) below it; the whole stated range lies below it.
By their numbers in this assay, from the lowest: compound 1; then compounds 2 and 3 (each within the scatter of the next); then compound 4.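

In this assay, putting hydrogen in place of (phenylsulfonyl)amino on the saturated chain carbon gives a 4000-fold higher number from compound 3 to compound 4 (3.60 log units; beyond the scatter), and the same removal of ((thiophen-2-yl)sulfonyl)amino gives a 6500-fold higher number from compound 2 to compound 4 (3.81 log units; beyond the scatter). The earlier swap of thiophen-2-yl for phenyl on the sulfonyl sulfur stayed within the scatter, so those compounds showed only that one of these two rings can stand in for the other; these large steps show that tight binding in this series is lost when the whole group is gone. The data shown give no explanation for the size of this loss.

Compound 4 loses the ring, the sulfonyl and the nitrogen together, so the compounds shown cannot say which of these parts matters, or whether all of them are needed. A plain amine on that saturated chain carbon, or a methylsulfonylamino group that keeps the sulfonyl and nitrogen but has no aromatic ring, would begin to separate these parts.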